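This account rests on a few compounds, and the source may have more. Where it says the series, first, only, none or still open, it means among the compounds named here.

Going by the values given here, compound 2 `O=C(Nc1nc2ccc([N+](=O)[O-])cc2s1)c1cccnc1Nc1ccc(Cl)cc1` gives 800 nM in an ADME assay on CV-1 cells (Chlorocebus aethiops) for inhibition, read by MTT assay, with a stated time of 48 h (a higher number here means a weaker inhibitor, a lower number a stronger inhibitor), the lowest of the two numbers so far. Among the compounds with values here, the nearest is compound 1 `O=C(Nc1nc2ccc([N+](=O)[O-])cc2s1)c1cccnc1Nc1ccc(F)cc1`, which in this assay gives 15000 nM, and the one measured step is a 19-fold lower number from compound 1 to compound 2 (1.27 log units; beyond the scatter). Compound 3 `COc1ccc(Nc2ncccc2C(=O)Nc2nc3ccc([N+](=O)[O-])cc3s2)cc1` carries methoxy in place of chloro on an aromatic carbon. Within the data shown here, no measured step covers methoxy, and compound 3 holds no halogen at that position, so the guide from a 19-fold lower number from compound 1 to compound 2 (1.27 log units; beyond the scatter) is indirect. The step is estimated as a 3.8-fold higher number from compound 2 to compound 3 (0.57 log units; beyond the scatter). Compound 3 is expected to give about 3000 nM in this assay, within 600 nM to 15000 nM.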

Compound 3, half-maximal inhibitory concentration: 10000 nM
The estimate for compound 3 lay 3.3-fold (0.52 log units) below the measured number, within the range that was stated.
By their numbers in this assay, from the lowest: compound 2; then compounds 3 and 1 (each within the scatter of the next).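

In this assay the low number at this position now stands with chloro alone among the three groups: methoxy in place of chloro loses it (a 13-fold higher number from compound 2 to compound 3 (1.10 log units; beyond the scatter)), while methoxy and fluoro do not separate (a 1.5-fold lower number from compound 1 to compound 3 (0.18 log units; within the scatter)). The earlier step from fluoro to chloro therefore reads as chloro set apart from both other groups. Nothing available explains this gap.

As far as these compounds go, whether bromo, methyl or trifluoromethyl at this position would fall with chloro or with fluoro and methoxy stays open. So does the outcome with an amine or a carboxylic acid there.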